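Aryl hydroxamate exchanged for an alkenyl hydroxamate

A few compounds are considered here, and "the series" means these few. Any claim that something is new, unique, unknown or untested is made for them only; others in the source may bear on it.

Measured so far, in an assay on Sf9 cells for inhibition of histone deacetylase 11 (Homo sapiens), read by fluorescence, tested at 0.5 uM; on this read-out higher numbers stand for more inhibition at the one concentration tested (going by the name of the read-out) and lower numbers for less inhibition:
compound 1 `O=C(NO)c1cccc(-c2cn([C@@H]3C[C@H](C(=O)O)N(Cc4ccccc4)C3)nn2)c1`: < 10%, a limit of the assay and not a number
compound 2 `O=C(NO)c1cccc(-c2cn([C@H]3C[C@@H](C(=O)O)N(Cc4ccccc4)C3)nn2)c1`: 14%

Compound 1 therefore stands at the reporting limit of this assay, the lowest position shown. Within the data shown here, compound 2 is its mirror image, and the one measured step, a number at least 4 percentage points higher from compound 1 to compound 2 (that floor lies within the scatter), concerns configuration alone. Among the measured compounds shown here, compound 3 `O=C(/C=C/c1cn([C@@H]2C[C@H](C(=O)O)N(Cc3ccccc3)C2)nn1)NO` carries 2-(hydroxycarbamoyl)ethenyl in place of 3-(hydroxycarbamoyl)phenyl on an aromatic carbon, a change on which no measured step bears, so no shift beyond the scatter is expected. Compound 3 is estimated at 10%, with a range of 0% to 25%. The step of a number no lower from compound 1 to compound 3 (the limit leaves the size open) is thus expected to stay within the scatter.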

Compound 3, a percentage reported as inhibition, at one concentration (the size of the read-out at that concentration, not a potency): < 10%
Compound 3 ended at the assay's limit; the forecaster's own chance of this, stated with the estimate: 50%; the middle value lies on the limit itself.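

Compound 1 and compound 3 both sit at the limit of the assay, so no step can be read between them. From the compounds shown here alone, whether 2-(hydroxycarbamoyl)ethenyl in place of 3-(hydroxycarbamoyl)phenyl changes the result in this assay at all stays open.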